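This account rests on a few compounds, and the source may have more. Where it says the series, first, only, none or still open, it means among the compounds named here.

Compound 3 `C/N=C1\S/C(=C\c2cc(C)n(Cc3c(F)cccc3F)c2C)C(=O)N1C` gives 34 nM in a functional assay for agonist activity at sphingosine 1-phosphate receptor 5 (Homo sapiens) (on this read-out higher numbers stand for an effect only at larger amounts of compound and lower numbers for an effect already at smaller amounts), the lowest of the three numbers shown, but neither gap from it reaches beyond the scatter: compound 2 `C/N=C1\S/C(=C\c2cc(C)n(Cc3ccc(F)cc3F)c2C)C(=O)N1C` gives 37 nM in this assay, and compound 1 `C/N=C1\S/C(=C\c2cc(C)n(Cc3ccccc3F)c2C)C(=O)N1C` gives 51 nM. Compound 4 `C/N=C1\S/C(=C\c2cc(C)n(Cc3ccccc3)c2C)C(=O)N1C` differs from compound 3 by one change: phenyl in place of 2,6-difluorophenyl on a saturated chain carbon bound to an aromatic nitrogen. Going by the values given here, two measured steps bear on it, since each added a fluorine to the ring that compound 4 carries bare: a 1.4-fold lower number from compound 1 to compound 2 (0.14 log units; within the scatter) and a 1.5-fold lower number from compound 1 to compound 3 (0.18 log units; within the scatter), both fluoro in place of hydrogen on an aromatic carbon, both within the scatter. The step of a 1.1-fold lower number from compound 2 to compound 3 (0.04 log units; within the scatter) moved a fluorine without leaving the scatter either. Removing both fluorines from compound 3 therefore undoes changes that were each small, so at most a modest rise in the number is expected, most likely one still within the scatter. Compound 4 is estimated at 65 nM in this assay, with a range from 30 nM to 140 nM, which amounts to an expected step of a 1.9-fold higher number from compound 3 to compound 4 (0.28 log units; within the scatter).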

Compound 4, half-maximal effective concentration: 144 nM
The estimate for compound 4 lay 2.2-fold (0.35 log units) below the measured number; measured number above the stated range.
By their numbers in this assay, from the lowest: compounds 3, 2 and 1 (each within the scatter of the next); then compound 4.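

With this compound, the ring on the saturated chain carbon bound to an aromatic nitrogen is shown to matter in this assay: phenyl in place of 2,6-difluorophenyl gives a 4.2-fold higher number from compound 3 to compound 4 (0.63 log units; beyond the scatter) and phenyl in place of 2,4-difluorophenyl gives a 3.9-fold higher number from compound 2 to compound 4 (0.59 log units; beyond the scatter) on the same read-out. Going by these compounds alone, the single fluorine of compound 1 already accounts for a step beyond the scatter, since hydrogen in its place gives a 2.8-fold higher number from compound 1 to compound 4 (0.45 log units; beyond the scatter) while the extra fluorine in compound 2 and compound 3 leaves the number within the scatter of compound 1. Nothing available explains why this loss of fluorine raises the number.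

As far as these compounds go, whether chloro, methyl or methoxy on this ring would keep the number as low as fluoro does remains open. So does the effect of replacing the phenyl with a pyridine ring.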